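Bromo substitution in the series: notes toward compound 4

The source may report more compounds than this note shows. Statements on the series, on what has been measured and on what is new or still open speak of the compounds shown alone.

Measured so far
compound 1, `O=c1cc(-c2ccccc2)oc2ccc(N3COc4c(Br)cc(Br)cc4C3)cc12`, in a functional assay on MCF7 cells (Homo sapiens) for inhibition, read by MTT assay, with a stated time of 48 h; a higher number here means a weaker inhibitor, a lower number a stronger inhibitor: "not active" (no number reported)
compound 2, `O=c1cc(-c2ccccc2)oc2ccc(N3COc4ccccc4C3)cc12`, in this assay: 27500 nM
compound 3, `O=c1cc(-c2ccccc2)oc2cc(N3COc4c(Br)cccc4C3)ccc12`, in this assay: "not active" (no number reported)

Within the data shown here, compound 2 holds the only number reported in this assay; compound 1 and compound 3 were both reported as not active, without a number attached. Both of those carry bromo substitution, and compound 3 further differs from compound 2 in how the shared core is joined. Among the measured compounds shown here, no step between measured compounds is available, so the effect of a single bromo group on this core has not been measured directly.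

Compound 4, `O=c1cc(-c2ccccc2)oc2ccc(N3COc4c(Br)cccc4C3)cc12`, differs from compound 2 by bromo in place of hydrogen on an aromatic carbon. With compound 1 and compound 3 returning no number in this assay, and compound 2 itself only weakly active at 27500 nM, the change is expected to move the result toward weaker inhibition, and there is a real chance that compound 4 is likewise reported as not active. For compound 4 a half-maximal inhibitory concentration of about 60000 nM is estimated, within a range of 25000 nM to 150000 nM. The expected step is a 2.2-fold higher number from compound 2 to compound 4 (0.34 log units; beyond the scatter), a loss beyond the usual scatter.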

Compound 4, half-maximal inhibitory concentration: 19600 nM
Estimate against measurement, compound 4: 3.1-fold (0.49 log units) above, and the stated range ends above it.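

In this assay the replacement of hydrogen by bromo on an aromatic carbon, ortho to a fused ring and meta to a fused ring, gives a 1.4-fold lower number from compound 2 to compound 4 (0.15 log units; within the scatter), so at this position the two compounds cannot be told apart. Compound 4 gives 19600 nM in this assay while compound 1, which differs from it by one further bromo, gives "not active" (no number reported) and compound 3, with the same bromo substitution but the shared core joined at a different place, gives "not active" (no number reported), so a single bromo at this position is not enough on its own to produce a not-active entry. Nothing at hand gives a measured reason for this result.

Still open, from the compounds shown here alone, is whether the position tolerates groups other than bromo, such as an amine, a carboxylic acid or a longer chain, or whether it merely tolerates this one atom without any gain over hydrogen. Also open, going by these compounds, is whether any group here can bring the number in this assay beyond the usual scatter from that of compound 2, and in which direction.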